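Removing the Methyl from an Aryl Oxygen: An Open Question

The source may hold more compounds than are shown below. What is called first, only, known or untested is meant among the compounds shown, and "the series" means these compounds.

In a functional assay on NCI-H322M cells (Homo sapiens) for inhibition, read by sulforhodamine B assay, with a stated time of 48 h (on this read-out higher numbers stand for weaker inhibition of growth and lower numbers for stronger inhibition of growth), compound 1 `COc1cc(-c2nn(-c3cccc(NC(=O)Nc4cc(C(F)(F)F)cc(C(F)(F)F)c4)c3)cc2-c2ccncc2)ccc1Cl` gives 3000 nM. Compound 2 `COc1cc(-c2nn(-c3cccc(NC(=O)Nc4ccc(Cl)c(Cl)c4)c3)cc2-c2ccncc2)ccc1Cl` is built on a different core; the difference between the two cores is not broken down here. In this assay compound 2 reaches only a limit of the assay, > 50000 nM. Compound 3 `O=C(Nc1cccc(-n2cc(-c3ccncc3)c(-c3ccc(Cl)c(O)c3)n2)c1)Nc1ccc(Cl)c(Cl)c1` derives from compound 2 through (hydrogen in place of methyl on an oxygen on an aromatic ring). In this assay compound 3 likewise returns only a limit, > 32500 nM. The step that the two limits leave unreadable from compound 2 to compound 3 therefore cannot be read, because compound 2 rests at the limit of > 50000 nM in this assay, at which 1 of the 3 values shown sits, and compound 3 at the limit of > 32500 nM in this assay, at which 1 of the 3 values shown sits.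

Compound 4 `O=C(Nc1cccc(-n2cc(-c3ccncc3)c(-c3ccc(Cl)c(O)c3)n2)c1)Nc1cc(C(F)(F)F)cc(C(F)(F)F)c1` has not yet been measured. It stands to compound 1 as compound 3 stands to compound 2, carrying (hydrogen in place of methyl on an oxygen on an aromatic ring), the same change at the same place. Going by the values given here, the sole measured instance of that change gives no readable size, so the expectation for compound 4 rests on compound 1 alone, anchored at 3000 nM. Compound 4 is accordingly expected to move from that anchor by a 1.7-fold higher number from compound 1 to compound 4 (0.22 log units; within the scatter), a modest step whose direction is uncertain. The estimate for compound 4 is 5000 nM, with a range from 1500 nM to 30000 nM.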

Compound 4, concentration for total growth inhibition: 5390 nM
For compound 4 the middle estimate is 1.1-fold (0.03 log units) below the measured one; the range from low to high includes it.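

In this assay, the change from 4-chloro-3-methoxyphenyl to 4-chloro-3-hydroxyphenyl on the core of compound 1 gives a 1.8-fold higher number from compound 1 to compound 4 (0.25 log units; within the scatter), so the two groups cannot be told apart on this core. On the core of compound 2 the same change cannot be read: compound 2 and compound 3 each stand at a limit of the assay, not at a number. The series therefore offers a single readable instance of the change, which shows neither that it behaves alike on the two cores nor that it behaves differently.

On these data alone, whether a longer chain on the same oxygen, such as ethyl or propyl, or an amine in place of the hydroxy would read differently from the methoxy and hydroxy groups stays open. Also open, as far as these compounds go, is how the change behaves on any further core that gives a number at both ends of the step.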